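Swapping amino for 4-chlorophenyl on the shared core

The compounds below may be only part of what the source reports. "The series", "measured", "known", "first", "only" and "open" are said of these compounds alone.

Within the data shown here, in an ADME assay on WI-38 cells (Homo sapiens) for cytotoxicity, read by sulforhodamine B assay, with a stated time of 24 h (on this read-out higher numbers stand for weaker inhibition and lower numbers for stronger inhibition), compound 1 `Cc1ccc(S(=O)(=O)N/N=C2\C(=O)Nc3ccc(S(=O)(=O)N4CCOCC4)cc32)cc1` gives 261000 nM and compound 2 `N/N=C1\C(=O)Nc2ccc(S(=O)(=O)N3CCOCC3)cc21` gives 391000 nM, so compound 2 stands level with its only neighbour within the scatter. Compound 3 `O=C1Nc2ccc(S(=O)(=O)N3CCOCC3)cc2/C1=N/c1ccc(Cl)cc1` carries 4-chlorophenyl in place of amino on a double-bonded nitrogen. Among the measured compounds shown here, the one measured step that bears on this, a 1.5-fold higher number from compound 1 to compound 2 (0.18 log units; within the scatter), put hydrogen in place of (4-methylphenyl)sulfonyl on an amine nitrogen and stayed within the scatter. A small drift to a lower number is therefore expected, estimated as a 1.8-fold lower number from compound 2 to compound 3 (0.25 log units; within the scatter). The expected value for compound 3 is 220000 nM, with a range of 90000 nM to 450000 nM.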

Compound 3, half-maximal inhibitory concentration: 468000 nM
Beside the measured number, compound 3's estimate is 2.1-fold (0.33 log units) below it; the measured number lies above the stated range.
By their numbers in this assay, from the lowest: compounds 1, 2 and 3 (each within the scatter of the next).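

In this assay, putting 4-chlorophenyl in place of amino on the double-bonded nitrogen gives a 1.2-fold higher number from compound 2 to compound 3 (0.08 log units; within the scatter) and so leaves the number level. This position therefore accepts a six-membered aromatic ring in place of amino with no change beyond the scatter, whereas the earlier step only altered what sat on the amine nitrogen. No measured evidence accounts for this result. Going by these compounds, whether a carboxylic acid or a longer amine chain on this nitrogen would move the number remains open. So does whether any group here can shift it beyond the scatter.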